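The source may hold more compounds than are shown below. What is called first, only, known or untested is meant among the compounds shown, and "the series" means these compounds.

Measured so far:
- compound 1, `Oc1cccc(-c2cc(-c3cccc(F)c3)cc(-c3ccccc3O)n2)c1`, in a functional assay on HCT-15 cells (Homo sapiens) for inhibition; on this read-out lower numbers stand for stronger inhibition and higher numbers for weaker inhibition: > 50000 nM
- compound 2, `Oc1cccc(-c2cc(-c3ccc(F)cc3)cc(-c3ccccc3O)n2)c1`: > 50000 nM
- compound 3, `Oc1ccc(-c2cc(-c3cccc(F)c3)cc(-c3ccccc3O)n2)cc1`: > 50000 nM

Compound 1 stands at a limit of this assay, not at a number; its value of > 50000 nM is such a limit. Compound 2 likewise sits at the limit, giving > 50000 nM. Compound 3 also sits at the limit with > 50000 nM. All three values share this position, as the limit of > 50000 nM in this assay, at which 3 of the 3 values shown sit, records, so the steps a step that the two limits leave unreadable from compound 1 to compound 2 and a step that the two limits leave unreadable from compound 1 to compound 3 cannot be read for size or direction.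

Compound 4, `Oc1cccc(-c2cc(-c3cccc(F)c3)cc(-c3cccc(O)c3)n2)c1`, has not yet been measured in this assay. It differs from compound 1 by 3-hydroxyphenyl in place of 2-hydroxyphenyl on an aromatic carbon. The two measured steps bear on it only in that every change so far, whether at the fluorophenyl or at a hydroxyphenyl, left the value at the limit; neither gives a readable size. Compound 4 is therefore expected to remain at or near the limit as well, estimated at 50000 nM with a range from 20000 nM to 200000 nM. The step this estimate implies is expected to be a number no higher from compound 1 to compound 4 (the limit leaves the size open).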

Compound 4, half-maximal inhibitory concentration: 7860 nM
Beside the measured number, compound 4's estimate is 6.4-fold (0.80 log units) above it, outside the stated range (below it).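

For the compounds shown here, exchanging 2-hydroxyphenyl for 3-hydroxyphenyl next to the ring nitrogen produces the only readable step so far in this assay, which is an at least 6.3-fold lower number from compound 1 to compound 4 (0.80 log units; beyond the scatter). Going by these compounds alone, the two compounds hold the same atoms joined differently, so this position responds to where the hydroxyl sits on that ring, whereas the earlier steps, which cannot be read, gave no such signal. Compound 4 alone among those shown gives a number rather than a limit: the limit of > 50000 nM in this assay, at which 3 of the 4 values shown sit.

As far as these compounds go, the true size of the step stays open, since one end of it is a limit, and so does whether 4-hydroxyphenyl at this position would give a number too. Also open, from the compounds shown here alone, is whether an amine or a carboxylic acid in place of the hydroxyl would keep the effect, or whether 4-fluorophenyl would keep it alongside 3-hydroxyphenyl.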